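This account rests on a few compounds, and the source may have more. Where it says the series, first, only, none or still open, it means among the compounds named here.

Going by the values given here, in a physicochemical assay for metabolic stability, read by HPLC, at pH 4.5, tested at 10 uM (on this read-out higher numbers stand for a longer-lived compound and lower numbers for a shorter-lived compound), compound 1 `Cc1ccccc1CNC(=O)n1cnc2ccccc21` gives 1.37 h and compound 2 `Cc1ccccc1CNC(=O)n1c(N)nc2ccccc21` gives 0.45 h as the lower of the two numbers so far. Among the compounds with values here, the only measured step of a 3.0-fold lower number from compound 1 to compound 2 (0.48 log units; beyond the scatter) is modest and lies at another place, so it sets no size for the next change. Compound 3 `Cc1ccc(CNC(=O)n2c(N)nc3ccccc32)cc1` carries 4-methylphenyl in place of 2-methylphenyl on a saturated chain carbon bound to an amide-type nitrogen with the shared core unchanged. In this assay no step beyond the scatter is expected. The estimated step of a 1.1-fold lower number from compound 2 to compound 3 (0.03 log units; within the scatter) has no firm direction. Compound 3 is estimated at 0.42 h (expected range 0.25 h to 0.75 h).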

Compound 3, half-life: 0.567 h
For compound 3 the middle estimate is 1.4-fold (0.13 log units) below the measured one; measured number inside the range.
By their numbers in this assay, from the lowest: compounds 2 and 3 (each within the scatter of the next); then compound 1.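

In this assay, 4-methylphenyl in place of 2-methylphenyl on a saturated chain carbon bound to an amide-type nitrogen gives a 1.3-fold higher number from compound 2 to compound 3 (0.10 log units; within the scatter). Going by these compounds alone, this is the first reading at this place, and the read-out does not separate these two groups there. Nothing available bears on the origin of this result.

Still open, on these data alone, is whether 3-methylphenyl, unsubstituted phenyl or a longer chain at this place would give a step beyond the scatter. Also open, as far as these compounds go, is whether the same exchange reads alike on the core of compound 1, which lacks the amino group.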